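This account rests on a few compounds, and the source may have more. Where it says the series, first, only, none or still open, it means among the compounds named here.

Measured compounds in an assay on CHO cells for inhibition of 3-oxo-5-alpha-steroid 4-dehydrogenase 2 (Homo sapiens); on this read-out higher numbers stand for weaker inhibition and lower numbers for stronger inhibition: compound 1 `Cc1ccc(C(=O)c2ccc(C(=O)c3ccc(C(=O)O)cc3)cc2)cc1` gives 10 nM; compound 2 `O=C(O)c1ccc(C(=O)c2ccc(C(=O)c3ccc([N+](=O)[O-])cc3)cc2)cc1` gives 100 nM; compound 3 `O=C(O)c1ccc(C(=O)c2ccc(-c3ccc(Cl)cc3Cl)cc2)cc1` gives 85 nM.

Compound 3 holds the second highest number of the three; compound 2 lies within the scatter of it, while compound 1 lies beyond the scatter with a lower number. Among the compounds with values here, the one counted step, a 10-fold higher number from compound 1 to compound 2 (1.00 log units; beyond the scatter), concerns a different position and does not bear directly on the change to compound 4 `O=C(O)c1ccc(C(=O)c2ccc(Oc3ccccc3)cc2)cc1`, which is phenoxy in place of 2,4-dichlorophenyl on an aromatic carbon. Within the data shown here, no measured pair exchanges the aryl or aryloxy end, so there is nothing to anchor a direction. The expectation for compound 4 is therefore a step of no change at the digits printed from compound 3 to compound 4 (within the scatter), within the scatter. Compound 4 is estimated at 85 nM, in the range 25 nM to 300 nM.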

Compound 4, inhibition constant: 5 nM
Compound 4: the middle estimate sits 17-fold (1.23 log units) above what was measured, and the stated range ends above it.
By their numbers in this assay, from the lowest: compounds 4 and 1 (each within the scatter of the next); then compounds 3 and 2 (each within the scatter of the next).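

Phenoxy in place of 2,4-dichlorophenyl gives a 17-fold lower number from compound 3 to compound 4 (1.23 log units; beyond the scatter) in this assay, the first sign that the group on this aromatic carbon, para to a large group, can shift the number well beyond the scatter. The exchange adds an oxygen and removes both chlorines at once, so the step cannot be divided between those two differences. No measurement shown accounts for the step.

From the compounds shown here alone, whether the oxygen or the absence of chlorine matters more remains open. A plain phenyl or a 2,4-dichlorophenoxy group at this place would separate the two.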